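Swapping a cycloheptyl for a methylpyrimidinyl on a triazole nitrogen

A few compounds are considered here, and "the series" means these few. Any claim that something is new, unique, unknown or untested is made for them only; others in the source may bear on it.

Three compounds share one core, a benzyl-bearing triazole carboxamide attached to a thione-containing bicyclic amine. Compound 1 is `CN1C(=S)[C@@H](NC(=O)c2nc(Cc3ccccc3)n(CCCCC#N)n2)COc2ccccc21`, compound 2 is `CN1C(=S)[C@@H](NC(=O)c2nc(Cc3ccccc3)n(C3CCCCCC3)n2)COc2ccccc21`, and the not yet measured compound 3 is `Cc1cnc(-n2nc(C(=O)N[C@H]3COc4ccccc4N(C)C3=S)nc2Cc2ccccc2)nc1`.

In a toxicity assay on HT-29 cells (Homo sapiens) for cytotoxicity (on this read-out lower numbers stand for higher toxicity in this test and higher numbers for lower toxicity in this test), compound 1 gives > 100000 nM, which is a limit of the assay rather than a number. In this assay compound 2 gives > 100000 nM, again a limit. The step that the two limits leave unreadable from compound 1 to compound 2 therefore cannot be read, because of the limit of > 100000 nM in this assay, at which 2 of the 2 values shown sit.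

So compound 2 stands only at a limit in this assay, and the one further value known is a limit as well. Compound 3 differs from compound 2 in one place: 5-methylpyrimidin-2-yl in place of cycloheptyl on an aromatic nitrogen.

Going by the values given here, the only measured step is unreadable, so no size can be expected for the step in this assay beyond that the two known compounds show no toxicity up to the limit. Compound 3 is expected to give 100000 nM, with a range from 30000 nM to 300000 nM. The step of a number no higher from compound 2 to compound 3 (the limit leaves the size open) is thus estimated as none.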

Compound 3, half-maximal cytotoxic concentration: > 100000 nM
Compound 3: no number, only a limit; the forecaster's own chance of this, stated with the estimate: 80%; the middle value lies on the limit itself.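

In this assay compound 3 gives > 100000 nM as a limit of the assay, not a number. Going by these compounds alone, no step between compound 1, compound 2 and compound 3 can be read, because all three stand at the same limit: the limit of > 100000 nM in this assay, at which 3 of the 3 values shown sit.

Going by these compounds, whether the group on the aromatic nitrogen changes toxicity in these cells at any higher concentration stays open.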